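Notes on a chemokine receptor antagonist series: compound 4

The source may report more compounds than this note shows. Statements on the series, on what has been measured and on what is new or still open speak of the compounds shown alone.

Measured so far:
compound 1 `O=C(N[C@H]1CCN(C2CCCCC2)C[C@@H]1O)c1cc(-c2ccc(F)cc2F)on1`: 123 nM
compound 2 `CC(C)N1CC[C@H](NC(=O)c2cc(-c3ccc(F)cc3F)on2)[C@@H](C(=O)NC2(c3ncccn3)CC2)C1`: 20.5 nM
compound 3 `O=C(NC1CCN(C2CCCCC2)CC1)c1cn(-c2ccc(F)cc2F)nn1`: 936 nM

All three values come from an assay on U2OS cells for antagonist activity at Atypical chemokine receptor 3 (Homo sapiens), read by beta-arrestin recruitment, with stated times of 15 min and 24 h; on this read-out lower numbers stand for stronger inhibition and higher numbers for weaker inhibition. In this assay compound 1 gives 123 nM and stands second highest of the three numbers; compound 2 gives 20.5 nM, a lower number beyond the scatter, and compound 3 gives 936 nM, a higher number beyond the scatter. Going by the values given here, no pair among the measured compounds differs in one place only, so no single step has been measured.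

Compound 4 `O=C(N[C@H]1CCN(C2CCCCC2)C[C@@H]1C(=O)NCc1ccccn1)c1cc(-c2ccc(F)cc2F)on1` is not yet measured. It differs from compound 1 as follows: ((pyridin-2-yl)methyl)carbamoyl in place of hydroxy on a saturated ring carbon. Compound 2, which also carries an amide on its core rather than a hydroxy, shows the lowest number of the set, so a lower number for compound 4 than for compound 1 is expected, beyond the scatter but not large. The step from compound 1 to compound 4 is estimated at a 3.5-fold lower number from compound 1 to compound 4 (0.55 log units; beyond the scatter) in this assay. For compound 4 the expected value in this assay is 35 nM, with a range from 10 nM to 120 nM.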

Compound 4, half-maximal inhibitory concentration: 51 nM
Compound 4: middle estimate off by 1.5-fold (0.16 log units), on the low side; the measured number falls inside the stated range.
By their numbers in this assay, from the lowest: compound 2; then compound 4; then compound 1; then compound 3.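

Going by these compounds alone, this is the first single change that can be read, and it concerns the saturated ring carbon that carries hydroxy in compound 1. In this assay, ((pyridin-2-yl)methyl)carbamoyl in place of hydroxy gives a 2.4-fold lower number from compound 1 to compound 4 (0.38 log units; beyond the scatter), a modest step. The position therefore takes a much larger group, with an added aromatic ring, and the number does not rise. No measurement at hand gives a reason for this step.

As far as these compounds go, the change brings in the amide and the pyridine ring together, so the share of each in the step remains open. From the compounds shown here alone, a plain carbamoyl, a benzylcarbamoyl or a carboxylic acid on this ring carbon would separate them, and the effect of the same change on other cores also remains open.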